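Methoxyphenyl to fluorophenyl on the alkyne arm

A few compounds are considered here, and "the series" means these few. Any claim that something is new, unique, unknown or untested is made for them only; others in the source may bear on it.

Compound 1 `COC(=O)c1sc2cc(C#Cc3ccccn3)cnc2c1N`: 13900 nM
Compound 2 `COC(=O)c1sc2cc(C#Cc3ccccc3OC)cnc2c1N`: > 47300 nM
Compound 3 `COC(=O)c1sc2cc(C#Cc3cccc(OC)c3)cnc2c1N`: > 75000 nM

In a functional assay on A375-C5 cells (Homo sapiens) for inhibition, read by sulforhodamine B assay, with a stated time of 48 h (a lower number here means a stronger inhibitor of growth, a higher number a weaker inhibitor of growth), compound 1 gives 13900 nM. For compound 2 the value > 47300 nM is a limit of this assay, not a number. For compound 3 the value > 75000 nM is likewise a limit of this assay, not a number, so compound 3 stands only as a bound among the three, together with one further limit (the limit of > 47300 nM in this assay, at which 1 of the 3 values shown sits).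

Compound 4 `COC(=O)c1sc2cc(C#Cc3ccc(F)cc3)cnc2c1N` differs from compound 3 in one place: 4-fluorophenyl in place of 3-methoxyphenyl on a triple-bonded carbon. Among the compounds with values here, the steps that bear on it both start from compound 1: an at least 3.4-fold higher number from compound 1 to compound 2 (0.53 log units; beyond the scatter) and an at least 5.3-fold higher number from compound 1 to compound 3 (0.73 log units; beyond the scatter). Between the two methoxyphenyl compounds the step that the two limits leave unreadable from compound 2 to compound 3, since both sit at limits the limit of > 47300 nM in this assay, at which 1 of the 3 values shown sits, and (the limit of > 75000 nM in this assay, at which 1 of the 3 values shown sits). Both measured changes away from pyridin-2-yl on the triple-bonded carbon weakened growth inhibition, and a 4-fluorophenyl is a further phenyl variant, so compound 4 is expected to remain a weak inhibitor, with a step of an at least 1.2-fold lower number from compound 3 to compound 4 (0.09 log units; that floor lies within the scatter) that is expected to be small or not readable. The estimate for compound 4 in this assay is 60000 nM, expected within 15000 nM to 150000 nM.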

Compound 4, concentration for 50% growth inhibition: 48400 nM
Estimate against measurement, compound 4: 1.2-fold (0.09 log units) above; measured number inside the range.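

In this assay compound 4 gives 48400 nM, the first phenyl variant on the triple-bonded carbon to read as a number and not a limit, so the loss on leaving pyridin-2-yl now has a measured size: a 3.5-fold higher number from compound 1 to compound 4 (0.54 log units; beyond the scatter). Against 3-methoxyphenyl, 4-fluorophenyl gives an at least 1.5-fold lower number from compound 3 to compound 4 (0.19 log units; that floor lies within the scatter), so no gain beyond the scatter is established. The step from compound 2 to compound 4 cannot be read, as compound 2 stands at a limit: the limit of > 47300 nM in this assay, at which 1 of the 4 values shown sits.

The compounds shown leave open whether the stronger value of compound 1 belongs to pyridin-2-yl in particular or would also appear with pyridin-3-yl on the triple-bonded carbon. They also leave open how a phenyl carrying an amine or a carboxylic acid would compare with 4-fluorophenyl.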